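Losing the Sulfonyl Arm: Expectations for Compound 3

This account rests on a few compounds, and the source may have more. Where it says the series, first, only, none or still open, it means among the compounds named here.

Measured so far:
Compound 1 `O=C1O[C@H]([C@@H](O)Cn2cc(CNS(=O)(=O)c3ccc(F)cc3)nn2)C(OCc2ccccc2)=C1OCc1ccccc1` — in a functional assay on MCF7 cells (Homo sapiens) for antiproliferative activity, read by MTT assay, with a stated time of 72 h (a higher number here means a weaker inhibitor, a lower number a stronger inhibitor), compound 1 gives 26800 nM.
Compound 2 `O=C1O[C@H]([C@@H](O)Cn2cc(CNS(=O)(=O)c3ccc(Cl)cc3)nn2)C(OCc2ccccc2)=C1OCc1ccccc1` — in this assay compound 2 gives 4170 nM.

Compound 2 stands at the lowest of the two numbers, and its nearest neighbour is compound 1, with the step of a 6.4-fold lower number from compound 1 to compound 2 (0.81 log units; beyond the scatter) beyond the scatter.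

Compound 3 `O=C1O[C@H]([C@@H](O)Cn2ccnn2)C(OCc2ccccc2)=C1OCc1ccccc1` is not yet measured. Its change from compound 2 is hydrogen in place of (((4-chlorophenyl)sulfonyl)amino)methyl on an aromatic carbon. Among the measured compounds shown here, no measured step removes this group; the only step that bears on it is a 6.4-fold lower number from compound 1 to compound 2 (0.81 log units; beyond the scatter), which shows that changing a single substituent on the 4-chlorophenyl part already shifts the number modestly. Removing the whole (((4-chlorophenyl)sulfonyl)amino)methyl group is a larger change, so a larger step is expected, most likely toward a higher number. Compound 3 is therefore estimated at 40000 nM, with a range of 8000 nM to 150000 nM, meaning an expected step of a 9.6-fold higher number from compound 2 to compound 3 (0.98 log units; beyond the scatter).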

Compound 3, half-maximal inhibitory concentration: > 100000 nM
Compound 3: no number, only a limit; the forecaster's own chance of this, stated with the estimate: 30%; at least 2.5-fold (0.39 log units) between middle value and limit.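

Compound 3 carries no number in this assay, only a limit of the assay: the limit of > 100000 nM in this assay, at which 1 of the 3 values shown sits. Replacing the (((4-chlorophenyl)sulfonyl)amino)methyl group with hydrogen gives an at least 23-fold higher number from compound 2 to compound 3 (1.37 log units; beyond the scatter), and replacing the (((4-fluorophenyl)sulfonyl)amino)methyl group with hydrogen gives an at least 3.7-fold higher number from compound 1 to compound 3 (0.57 log units; beyond the scatter). The earlier compounds shown here showed only that the halogen on the arm shifts the number, whereas these steps show that the numbers of both compounds depend on the substituent at this aromatic carbon of the five-membered ring, since the core with hydrogen there gives only a limit.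

From the compounds shown here alone, it remains open how far the true value of compound 3 lies past its limit. Going by these compounds, it is also open which part of the arm matters, and whether a plain aminomethyl group or a benzyl group at this carbon would restore a measurable number.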